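Sulfonyl aryl swap: 4-nitrophenyl in place of 3-nitrophenyl

This account rests on a few compounds, and the source may have more. Where it says the series, first, only, none or still open, it means among the compounds named here.

Three members of the series share one core and differ only in the aryl group on the sulfonyl sulfur. In a functional assay on PC-3 cells (Homo sapiens) for inhibition (a lower number here means a stronger inhibitor, a higher number a weaker inhibitor), compound 1 `COc1cc2nc(N3CCN(S(=O)(=O)c4ccc(Cl)s4)CC3)nc(N)c2cc1OC` gives 25000 nM, compound 2 `COc1cc2nc(N3CCN(S(=O)(=O)c4ccccc4[N+](=O)[O-])CC3)nc(N)c2cc1OC` gives 35000 nM, and compound 3 `COc1cc2nc(N3CCN(S(=O)(=O)c4cccc([N+](=O)[O-])c4)CC3)nc(N)c2cc1OC` gives 32000 nM. Compound 3 holds the second highest of the three numbers in this assay, but its neighbours sit close: a 1.1-fold lower number from compound 2 to compound 3 (0.04 log units; within the scatter), and a 1.3-fold higher number from compound 1 to compound 3 (0.11 log units; within the scatter).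

The next step is compound 4 `COc1cc2nc(N3CCN(S(=O)(=O)c4ccc([N+](=O)[O-])cc4)CC3)nc(N)c2cc1OC`, with the change (4-nitrophenyl in place of 3-nitrophenyl on a sulfonyl sulfur). Among the compounds with values here, the steps that bear on it are the three aryl swaps on the same sulfur: a 1.4-fold higher number from compound 1 to compound 2 (0.15 log units; within the scatter), a 1.3-fold higher number from compound 1 to compound 3 (0.11 log units; within the scatter) and a 1.1-fold lower number from compound 2 to compound 3 (0.04 log units; within the scatter). None of them moved the number beyond the scatter, so no step beyond the scatter is expected in this assay for the shift to the 4-nitrophenyl either. The estimated step is no change at the digits printed from compound 3 to compound 4 (within the scatter). Compound 4 is therefore expected to give about 32000 nM in this assay, within a range of 15000 nM to 65000 nM.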

Compound 4, half-maximal inhibitory concentration: 36000 nM
The estimate for compound 4 lay 1.1-fold (0.05 log units) below the measured number; low and high end bracket the measured number.
By their numbers in this assay, from the lowest: compounds 1, 3, 2 and 4 (each within the scatter of the next).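

The series now carries 2-nitrophenyl, 3-nitrophenyl and 4-nitrophenyl on the same sulfonyl sulfur, and moving the nitro group does not separate them in this assay: there is a 1.1-fold higher number from compound 3 to compound 4 (0.05 log units; within the scatter), and a 1.0-fold higher number from compound 2 to compound 4 (0.01 log units; within the scatter). The 5-chlorothiophen-2-yl compound does not separate from the new compound either, with a 1.4-fold higher number from compound 1 to compound 4 (0.16 log units; within the scatter), so all four aryl groups at this place read alike within the scatter. No supporting data bear on why these groups read alike.

Still open, going by these compounds, is whether any change on this sulfur can move the number beyond the scatter in this assay. A phenyl ring bearing an amine or a carboxylic acid, or a longer alkyl chain in place of the aryl group, would test this.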